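Trimming the Ether Arm of a Naphthyl Carbinol

A few compounds are considered here, and "the series" means these few. Any claim that something is new, unique, unknown or untested is made for them only; others in the source may bear on it.

Compound 1 `CCOC(=O)C(C)C(O)(c1ccc(OC)c(OC)c1OC)c1cccc2ccccc12`: > 20000 nM
Compound 2 `COc1cc(COC(c2ccc(OC)c(OC)c2OC)c2cccc3ccccc23)cc(OC)c1`: > 20000 nM

In a functional assay on MCF7 cells (Homo sapiens) for inhibition, read by sulforhodamine B assay, with a stated time of 48 h (a lower number here means a stronger inhibitor, a higher number a weaker inhibitor), compound 1 reaches only the assay limit, > 20000 nM. Compound 2 likewise gives only a limit in this assay, > 20000 nM. Compound 2 therefore stands at the limit of > 20000 nM in this assay, at which 2 of the 2 values shown sit, and no number separates it from compound 1. For the measured compounds named here, compound 3 `C=CCOC(c1ccc(OC)c(OC)c1OC)c1cccc2ccccc12` differs from compound 2 by vinyl in place of 3,5-dimethoxyphenyl on a saturated chain carbon bound to an oxygen on a saturated carbon, a change for which no measured step exists here. The step that the limit leaves unreadable from compound 2 to compound 3 is expected to be none beyond the scatter, with compound 3 most likely again at the limit. Compound 3 is estimated at 25000 nM, between 6000 nM and 80000 nM.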

Compound 3, half-maximal inhibitory concentration: > 20000 nM
Compound 3: only a limit was reported; the forecaster's own chance of this, stated with the estimate: 70%; the middle value is on the limit's open side.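

Compound 3 gives only a limit in this assay, > 20000 nM. No step can be read between compound 2 and compound 3. The compounds shown leave open whether trading 3,5-dimethoxybenzyl for allyl alters inhibition at all: the limit of > 20000 nM in this assay, at which 3 of the 3 values shown sit.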